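Swapping Pyridin-2-yl for Phenyl: Expected Cytotoxicity

The source may report more compounds than this note shows. Statements on the series, on what has been measured and on what is new or still open speak of the compounds shown alone.

Compound 1 `Oc1ccc(-c2cc(-c3ccccc3)nc(-c3ccccc3Cl)c2)cc1`: 2800 nM
Compound 2 `Oc1cccc(-c2cc(-c3cccnc3)nc(-c3ccccc3Cl)c2)c1`: "not determined" (no result reported)
Compound 3 `Oc1cccc(-c2cc(-c3ccccn3)nc(-c3ccccc3Cl)c2)c1`: "not determined" (no result reported)

In a functional assay on DU-145 cells (Homo sapiens) for cytotoxicity, read by CCK-8 assay and cell counting, with a stated time of 2 days (a lower number here means a stronger inhibitor, a higher number a weaker inhibitor), compound 1 gives 2800 nM. Compound 2 gives "not determined" (no result reported) in this assay, and compound 3 likewise gives "not determined" (no result reported). Compound 3 therefore stands without a number of its own, and the only figure in the set comes from compound 1.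

Compound 4 `Oc1cccc(-c2cc(-c3ccccc3)nc(-c3ccccc3Cl)c2)c1` differs from compound 3 in one place: phenyl in place of pyridin-2-yl on an aromatic carbon. Within the data shown here, since neither compound 3 nor compound 2 carries a number, no measured step is available to judge the size or direction of this change, and the scatter of repeated measurements sets the floor of any uncertainty.

Among the measured compounds shown here, the expectation for compound 4 rests on the single number of compound 1, which shares the core, the 2-chlorophenyl group and the phenyl group. Compound 4 is expected to give about 3000 nM, with a range from 800 nM to 12000 nM.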

Compound 4, half-maximal inhibitory concentration: 1480 nM
Compound 4: middle estimate off by 2.0-fold (0.31 log units), on the high side; low and high end bracket the measured number.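

In this assay, 3-hydroxyphenyl in place of 4-hydroxyphenyl gives a 1.9-fold lower number from compound 1 to compound 4 (0.28 log units; within the scatter), so the two placements of the hydroxyl group cannot be told apart here. As far as these compounds go, the step from pyridin-2-yl to phenyl cannot be read: compound 3 has no number, so what the ring nitrogen contributes remains unknown. No measurement shown offers an explanation for the result. The compounds shown leave open how a simple amine or a carboxylic acid would fare in place of the phenyl group, on the aromatic carbon next to the ring nitrogen.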